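From Hydrogen to Ethyl on a Sulfonamide Nitrogen

A few compounds are considered here, and "the series" means these few. Any claim that something is new, unique, unknown or untested is made for them only; others in the source may bear on it.

Of the compounds shown here, three sharing one core have been measured in a physicochemical assay for lipophilicity; on this read-out higher numbers stand for higher lipophilicity and lower numbers for lower lipophilicity. For compound 1 `C[n+]1ccn(CCOCCS(C)(=O)=O)c1/C=N/O` this assay reports only a limit, < -3, which is the limit of < -3 in this assay, at which 1 of the 3 values shown sits. Compound 2 `CCN(CC)CCCn1cc[n+](C)c1/C=N/O` gives -2.78 in this assay. Compound 3 `C[n+]1ccn(CCCNS(=O)(=O)C(F)(F)F)c1/C=N/O` gives -1.26 in this assay, the higher of the two numbers, with compound 2 standing lower by a gap beyond the usual scatter. The step now followed leads to compound 4 `CCN(CCCn1cc[n+](C)c1/C=N/O)S(=O)(=O)C(F)(F)F`, which differs from compound 3 by ethyl in place of hydrogen on a sulfonamide nitrogen. Going by the values given here, no measured pair shows such a change, so the size of the step is open. The step in this assay is expected to be a number 0.71 log units higher from compound 3 to compound 4 (beyond the scatter), upward and beyond the usual scatter. Compound 4 is estimated at -0.55, between -1.15 and 0.05.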

Compound 4, distribution coefficient: -1.02
Estimate against measurement, compound 4: 0.47 log units above; measured number inside the range.
By their numbers in this assay, from the lowest: compound 2; then compounds 3 and 4 (each within the scatter of the next). At a limit, below all of these: compound 1.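

On a sulfonamide nitrogen, ethyl in place of hydrogen gives a number 0.24 log units higher from compound 3 to compound 4 (within the scatter) in this assay and so makes no clear difference here. The much larger change comes from (trifluoromethyl)sulfonyl in place of ethyl on an amine nitrogen, which gives a number 1.76 log units higher from compound 2 to compound 4 (beyond the scatter) on the same scale. No measurement shown explains either step. Still open, as far as these compounds go, is whether a longer chain on the sulfonamide nitrogen would also stay within the scatter of compound 3. A carboxylic acid or an amine on a chain at this nitrogen also remains untested among the compounds shown.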